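Amide-cap variation on the shared core

The compounds below may be only part of what the source reports. "The series", "measured", "known", "first", "only" and "open" are said of these compounds alone.

Compound 1 `COc1ccccc1C#Cc1nc2c(s1)C(=O)NCC2` gives only a limit in an assay on HEK293 cells for negative allosteric modulation of metabotropic glutamate receptor 5 (Homo sapiens), read by FLIPR, with a stated time of 1 h (a lower number here means a stronger inhibitor, a higher number a weaker inhibitor), namely > 10000 nM. Compound 2 `Cc1cccc(C#Cc2nc3c(s2)C(=O)NCC3)c1` likewise sits at a limit, > 10000 nM. Among the measured compounds shown here, compound 3 `O=C(C1CC1)N1CCc2nc(C#Cc3ccccc3)sc2C1` is the one member with a measured number, 290 nM in this assay, and so stands alone as the single quantified point. The other two values sit at the limit of > 10000 nM in this assay, at which 2 of the 3 values shown sit, and allow no ordering of compound 1 or compound 2 against compound 3. Compound 4 `Cc1nc(C(=O)N2CCc3nc(C#Cc4ccccc4)sc3C2)cs1` differs from compound 3 by 2-methyl-1,3-thiazol-4-yl in place of cyclopropyl on a carbonyl carbon. For the measured compounds named here, no measured pair shows such an exchange, so its size is not known from these data. For compound 4 the expected step is a 1.9-fold lower number from compound 3 to compound 4 (0.29 log units; within the scatter), a modest gain beyond the scatter. Compound 4 is accordingly estimated at 150 nM in this assay, within 40 nM to 700 nM.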

Compound 4, half-maximal inhibitory concentration: > 10000 nM
Compound 4 gave a limit, no number; the forecaster's own chance of this, stated with the estimate: 5%; middle value at least 66-fold (1.82 log units) away from the limit.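

The exchange of cyclopropyl for 2-methyl-1,3-thiazol-4-yl on a carbonyl carbon gives an at least 34-fold higher number from compound 3 to compound 4 (1.53 log units; beyond the scatter) in this assay, so the cap at this position strongly affects the read-out. Compound 4 gives a limit and not a number, so the step has a lower bound only. Compound 3 remains the only quantified member: the limit of > 10000 nM in this assay, at which 3 of the 4 values shown sit.

From the compounds shown here alone, it remains open whether the drop belongs to the ring of the 2-methyl-1,3-thiazol-4-yl group or to its methyl. A plain 1,3-thiazol-4-yl, a phenyl or a cyclobutyl cap on the same carbonyl carbon would bear on this.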